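The compounds below may be only part of what the source reports. "The series", "measured", "known", "first", "only" and "open" are said of these compounds alone.

Measured in a functional assay on MCF7 cells (Homo sapiens) for inhibition; a higher number here means a weaker inhibitor, a lower number a stronger inhibitor:
- compound 1 `CCCC/C=C/C=C/[C@@]1(C)SC(O)=CC1=O`: 22.6 ug/mL
- compound 2 `CCCCCC[C@@]1(C)SC(O)=CC1=O`: 16.5 ug/mL
- compound 3 `CCCCCCCC[C@@]1(C)SC(O)=CC1=O`: 12.6 ug/mL

Compound 3 gives 12.6 ug/mL, and all three numbers lie within the scatter of one another. On these data, compound 3 therefore cannot be separated from the other two.

Compound 4 `C=CCC1=C(O)S[C@](C)(CCCCCCCC)C1=O` keeps the chain of compound 3 but takes allyl in place of hydrogen on a double-bonded ring carbon. This carbon stands next to the ring atom that bears a hydroxy group.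

Among the compounds with values here, only one measured step connects compounds that differ in a single place: a 1.3-fold lower number from compound 2 to compound 3 (0.12 log units; within the scatter). That step is small and lies on the chain, not on the ring, so it bears on the new change only indirectly. Within the data shown here, no measured compound carries a group at this ring carbon, which leaves the data without a direct guide. The three chains tried so far have kept the numbers within the scatter, and that offers only a weak reason to expect a similarly small change here. The expected change is a 1.1-fold lower number from compound 3 to compound 4 (0.06 log units; within the scatter), which is no step beyond the scatter, although a larger move in either direction remains possible at this untested place. The estimate for compound 4 is 11 ug/mL, with an expected range from 4.5 ug/mL to 27 ug/mL.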

Compound 4, half-maximal inhibitory concentration: 34.8 ug/mL
Beside the measured number, compound 4's estimate is 3.2-fold (0.50 log units) below it; measured number above the stated range.
By their numbers in this assay, from the lowest: compounds 3, 2, 1 and 4 (each within the scatter of the next, the first and the last beyond it).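

In this assay, within the data shown here, the double-bonded ring carbon responds to substitution: allyl in place of hydrogen gives a 2.8-fold higher number from compound 3 to compound 4 (0.44 log units; beyond the scatter), a modest change toward a weaker inhibitor and the only step in this set that lies beyond the scatter. The earlier compounds differed only in the chain, and their one listed step stayed within the scatter, so they said nothing about this ring carbon; this result shows that the position cannot be assumed to tolerate a new group without effect on the number. No available evidence accounts for the rise, so it stands as an observation without an explanation.

A single group at this ring carbon cannot show whether the rise belongs to allyl in particular or would follow from any group placed there. Still open, going by these compounds, is whether methyl, a saturated propyl group or an amine at this carbon would give a similar number, and whether allyl on the shorter chain of compound 2 would produce a step of like size.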